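This account rests on a few compounds, and the source may have more. Where it says the series, first, only, none or still open, it means among the compounds named here.

Working notes on the series. In a functional assay on HEK293 cells for antagonist activity at transient receptor potential cation channel subfamily V member 1 (Rattus norvegicus) (a higher number here means a weaker inhibitor, a lower number a stronger inhibitor), compound 1 `CC(C)(C)c1ccc(NC(=O)N2CCN(c3ncccc3C(F)(F)F)CC2)cc1` gives 11.3 nM. In this assay compound 2 `CC(C)c1ccc(NC(=O)N2CCN(c3ncccc3[N+](=O)[O-])CC2)cc1` gives 190 nM, and in this assay compound 3 `CC(C)c1ccc(NC(=O)N2CCN(c3ncccc3Cl)CC2)cc1` gives 11.5 nM. Compound 3 thus stands second highest of the three numbers; its nearest neighbour is compound 1, with which it sits within the scatter, and its furthest is compound 2, which lies well beyond it. Among the measured compounds shown here, the one single-point step recorded is a 17-fold lower number from compound 2 to compound 3 (1.22 log units; beyond the scatter), a large move. Compound 1 differs from compound 3 in two places at once, so its value is only a second point at about the same level, not a step.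

Compound 4 `CC(C)c1ccc(NC(=O)N2CCN(c3ncccc3Br)CC2)cc1` is the next step: bromo in place of chloro on an aromatic carbon. For the measured compounds named here, no measured step exchanges one halogen for another; the only recorded step, a 17-fold lower number from compound 2 to compound 3 (1.22 log units; beyond the scatter), concerns a different pair of groups and gives no direct guide here. Nothing among the three measured compounds argues for a large move in either direction. The step from compound 3 to compound 4 is therefore expected to be a 1.2-fold lower number from compound 3 to compound 4 (0.06 log units; within the scatter), nothing beyond the scatter. Compound 4 is expected to give 10 nM in this assay, with a range of 4 nM to 30 nM.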

Compound 4, half-maximal inhibitory concentration: 4.6 nM
Compound 4: middle estimate off by 2.2-fold (0.34 log units), on the high side; the measured number falls inside the stated range.
By their numbers in this assay, from the lowest: compound 4; then compounds 1 and 3 (each within the scatter of the next); then compound 2.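

At the position two atoms from the ring nitrogen, exchanging one halogen for another is not silent in this assay: bromo in place of chloro gives a 2.5-fold lower number from compound 3 to compound 4 (0.40 log units; beyond the scatter), a modest move but one beyond the scatter, so this position distinguishes between two halogens as well as between a halogen and nitro. Replacing nitro with bromo gives a 41-fold lower number from compound 2 to compound 4 (1.62 log units; beyond the scatter), and across compound 2, compound 3 and compound 4 the numbers fall in the order nitro, chloro, bromo, with each listed step beyond the scatter and no compound among these three going against that order. Nothing measured here accounts for the difference between chloro and bromo.

As far as these compounds go, whether the order extends to iodo, or what a methyl, methoxy or nitrile group would give at this position, remains open, since the comparison rests on nitro, chloro and bromo alone. Among the compounds shown here, also open is whether bromo in place of chloro would have a similar effect in the setting of compound 1, which differs from compound 3 in two places and so gives no step here.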